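The compounds below may be only part of what the source reports. "The series", "measured", "known", "first", "only" and "open" are said of these compounds alone.

Compound 1 `NC(=O)c1c(NC(=O)c2ccccc2Cl)sc2c1CCN(Cc1ccccc1F)C2` gives 12900 nM in a functional assay on MKN-74 cells (Homo sapiens) for antiproliferative activity, with a stated time of 24 h; on this read-out higher numbers stand for weaker inhibition and lower numbers for stronger inhibition.
Compound 2 `NC(=O)c1c(NC(=O)c2ccc(C(F)(F)F)cc2)sc2c1CCN(Cc1ccccc1F)C2` gives 26900 nM.
Compound 3 `NC(=O)c1c(NC(=O)c2ccccc2Cl)sc2c1CCN(C(=S)Nc1ccccc1I)C2` gives 2630 nM.

Among these three, compound 2 carries the highest number: the step of a 2.1-fold higher number from compound 1 to compound 2 (0.32 log units; beyond the scatter) separates it from its nearest neighbour, and the gap to compound 3 is wider still. Compound 4 `NC(=O)c1c(NC(=O)c2ccc(C(F)(F)F)cc2)sc2c1CCN(C(=O)Nc1ccccc1Cl)C2` is built from compound 2 by (2-chlorophenyl)carbamoyl in place of 2-fluorobenzyl on an amine nitrogen in a ring. Going by the values given here, one measured step bears on this: a 4.9-fold lower number from compound 1 to compound 3 (0.69 log units; beyond the scatter), where the same 2-fluorobenzyl on the ring amine nitrogen was also exchanged for a larger group carrying a second aromatic ring on a nitrogen. The new group in compound 4 is of similar kind, so a step of comparable size and the same direction is expected, a 3.4-fold lower number from compound 2 to compound 4 (0.53 log units; beyond the scatter). Compound 4 is therefore estimated at 8000 nM, within 2500 nM to 25000 nM.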

Compound 4, half-maximal inhibitory concentration: 43900 nM
Estimate against measurement, compound 4: 5.5-fold (0.74 log units) below; the measured number lies above the stated range.
By their numbers in this assay, from the lowest: compound 3; then compound 1; then compounds 2 and 4 (each within the scatter of the next).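

In this assay, putting (2-chlorophenyl)carbamoyl in place of 2-fluorobenzyl on the ring amine nitrogen gives a 1.6-fold higher number from compound 2 to compound 4 (0.21 log units; within the scatter), so these two groups are not told apart here. The lower number in a 4.9-fold lower number from compound 1 to compound 3 (0.69 log units; beyond the scatter) therefore does not extend to every larger group with a second aromatic ring on this nitrogen. No measurement shown explains this result. As far as these compounds go, compounds 3 and 4 differ in more than one place, so the source of their difference remains open. Also open, from the compounds shown here alone, is how a simple methyl or a short aminoethyl chain on this nitrogen would behave.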